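From 3-fluorophenyl to pyridin-4-yl: expected shift for compound 4

This account rests on a few compounds, and the source may have more. Where it says the series, first, only, none or still open, it means among the compounds named here.

In a functional assay on B16-F10 cells (Mus musculus) for antiproliferative activity, read by MTT assay, with a stated time of 48 h (on this read-out higher numbers stand for weaker inhibition and lower numbers for stronger inhibition), compound 1 `CC(=O)N1N=C(c2ccc3ccccc3c2)OC1c1ccccc1` gives 2.57 ug/mL, compound 2 `COc1ccc(C2OC(c3ccc4ccccc4c3)=NN2C(C)=O)cc1` gives 6.86 ug/mL and compound 3 `CC(=O)N1N=C(c2ccc3ccccc3c2)OC1c1cccc(F)c1` gives 1.61 ug/mL. Compound 3 thus sits with compound 1 at the low end: a 1.6-fold lower number from compound 1 to compound 3 (0.20 log units; within the scatter) stays inside the scatter, while a 4.3-fold lower number from compound 2 to compound 3 (0.63 log units; beyond the scatter) goes beyond it. Compound 4 `CC(=O)N1N=C(c2ccc3ccccc3c2)OC1c1ccncc1` carries pyridin-4-yl in place of 3-fluorophenyl on a saturated ring carbon. Within the data shown here, no measured step introduces a ring nitrogen, so the evidence is indirect. Among the measured aryl changes, the methoxy step a 2.7-fold higher number from compound 1 to compound 2 (0.43 log units; beyond the scatter) is modest and a 1.6-fold lower number from compound 1 to compound 3 (0.20 log units; within the scatter) lies within the scatter. A modest rise is expected in this assay, estimated as a 2.2-fold higher number from compound 3 to compound 4 (0.34 log units; beyond the scatter). For compound 4 the estimated value is 3.5 ug/mL, with an expected range of 1.3 ug/mL to 9 ug/mL.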

Compound 4, half-maximal inhibitory concentration: 2.97 ug/mL
Compound 4: middle estimate off by 1.2-fold (0.07 log units), on the high side; the measured number falls inside the stated range.
By their numbers in this assay, from the lowest: compounds 3, 1 and 4 (each within the scatter of the next); then compound 2.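

In this assay, among these compounds, pyridin-4-yl on the saturated ring carbon shows that a ring nitrogen can enter the aryl group without a shift beyond the scatter: a 1.2-fold higher number from compound 1 to compound 4 (0.06 log units; within the scatter) and a 1.8-fold higher number from compound 3 to compound 4 (0.27 log units; within the scatter) both stay inside it. a 2.3-fold lower number from compound 2 to compound 4 (0.36 log units; beyond the scatter) is the only new step beyond it, so compound 2 remains apart from the other three. No measurement at hand accounts for these steps.

The compounds shown leave open how pyridin-3-yl would read at this carbon. Also open, on these data alone, is whether an amine or a carboxylic acid on the aryl ring would give a step beyond the scatter.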